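Opening a cyclic amidine on a chroman amine chain

A few compounds are considered here, and "the series" means these few. Any claim that something is new, unique, unknown or untested is made for them only; others in the source may bear on it.

Compound 1, `COc1ccc2c(c1)OC(CNCCCNC1=NCCCN1)CC2`: in an assay on isolated protein (Bos taurus) with 5-hydroxytryptamine receptor 1D (Homo sapiens) as the target (on this read-out higher numbers stand for weaker inhibition and lower numbers for stronger inhibition), compound 1 gives 3.16 nM.
Compound 2, `c1ccc2c(c1)CCCC(CNCCCNC1=NCCCN1)O2`: compound 2 returns only a limit of the assay, > 1000 nM.
Compound 3, `c1ccc2c(c1)CCC(CNCCCNC1=NCCN1)O2`: compound 3 gives 6.31 nM.

Compound 3 holds the higher of the two numbers reported in this assay. Its nearest neighbour is compound 1, whose number lies lower by a margin that stays within the usual scatter, so the two cannot be ranked against each other. Compound 2 is reported only as the limit of > 1000 nM in this assay, at which 1 of the 3 values shown sits, which is a limit and not a number.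

Compound 4, `CC(C)/N=C(\N)NNCCCNCC1CCc2ccccc2O1`, differs from compound 3 in one place: a group of 7 heavy atoms (4 carbon, 3 nitrogen; no ring) in place of a group of 5 heavy atoms (3 carbon, 2 nitrogen; one five-membered non-aromatic ring with 2 hetero atoms), on an amine nitrogen. Among the compounds with values here, no step between two measured compounds is available to calibrate this change, so the expectation rests on the change itself and on where compound 3 stands. A moderate loss, reaching beyond the scatter, is expected from compound 3 to compound 4, so that a 6.3-fold higher number from compound 3 to compound 4 (0.80 log units; beyond the scatter) describes the anticipated step. For compound 4 the estimate in this assay is 40 nM, with a range from 6 nM to 300 nM.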

Compound 4, half-maximal inhibitory concentration: 3.16 nM
Compound 4: the middle estimate sits 13-fold (1.10 log units) above what was measured; the measured number lies below the stated range.
By their numbers in this assay, from the lowest: compounds 1, 4 and 3 (each within the scatter of the next). At a limit, above all of these: compound 2.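

Going from a ring to an open group on this amine nitrogen left the result in this assay unchanged within the scatter (a 2.0-fold lower number from compound 3 to compound 4 (0.30 log units; within the scatter)). Until now, compounds 1, 2 and 3 had shown this place only with a ring, so compound 4 is the first to show that a group with no ring, of 7 heavy atoms (4 carbon, 3 nitrogen), can stand here in place of the five-membered non-aromatic ring with 2 hetero atoms and still give a value in the same range as compound 3. Nothing among the data offered bears on why this exchange is so well accepted.

The compounds shown leave open how far this acceptance reaches, since a single open group stands here and the effect of a benzyl group or a longer chain at its end remains unknown. They also leave open whether the same open group would hold its value on the core of compound 1, which carries a methoxy group.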